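Replacing Iodine with Thiophene on a Nucleoside Core

The source may report more compounds than this note shows. Statements on the series, on what has been measured and on what is new or still open speak of the compounds shown alone.

Compound 1 `Cc1ncnc2c1c(I)cn2[C@@H]1O[C@H](CO)[C@@H](O)[C@H]1O` gives 13300 nM in an ADME assay on MRC5 cells (Homo sapiens), read by MTT assay, with a stated time of 72 h; a higher number here means a weaker inhibitor, a lower number a stronger inhibitor
Compound 2 `COc1ncnc2c1c(-c1ccoc1)cn2[C@@H]1O[C@H](CO)[C@@H](O)[C@H]1O` gives 29400 nM in this assay
Compound 3 `Nc1nc2c(c(-c3ccco3)cn2[C@@H]2O[C@H](CO)[C@@H](O)[C@H]2O)c(=O)[nH]1` gives > 100000 nM in this assay

Of the compounds shown here, three sharing a nucleoside core have been measured in this assay. Of the two that gave numbers, compound 1 stands lowest, meaning it is the stronger inhibitor of the pair, and the gap to compound 2 lies beyond the usual scatter. Compound 3 gave only a limit of the assay, not a number, so it cannot be placed in order with the others, as the limit of > 100000 nM in this assay, at which 1 of the 3 values shown sits, shows.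

The next compound, compound 4 `Cc1ncnc2c1c(-c1cccs1)cn2[C@@H]1O[C@H](CO)[C@@H](O)[C@H]1O`, has not yet been measured in this assay. It is built from compound 1 by one change: thiophen-2-yl in place of iodo on an aromatic carbon. Both compound 2 and compound 3 carry a five-membered aromatic ring at the corresponding position, and both gave weaker results than compound 1, which suggests that swapping the single iodine for a larger ring may push the number upward.

The step from compound 1 to compound 4 is therefore expected to be modest but upward, a 1.9-fold higher number from compound 1 to compound 4 (0.27 log units; within the scatter). Compound 4 is estimated at 25000 nM, with a range from 8000 nM to 90000 nM.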

Compound 4, half-maximal inhibitory concentration: > 100000 nM
Compound 4: a limit, no number; the forecaster's own chance of this, stated with the estimate: 20%; at least 4.0-fold (0.60 log units) between middle value and limit.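

Going by these compounds alone, exchanging iodo for thiophen-2-yl on this aromatic carbon, with the rest of the molecule unchanged, gives an at least 7.5-fold higher number from compound 1 to compound 4 (0.87 log units; beyond the scatter) in this assay, and this is the first step here that isolates a single place. Within the data shown here, compound 4 gives only a limit of the assay, not a number, so the step has a lower bound but no measured size, and compound 4 sits at the same limit as compound 3: the limit of > 100000 nM in this assay, at which 2 of the 4 values shown sit. Compound 2 and compound 3 also carry a five-membered aromatic ring at this position but differ from compound 1 elsewhere as well, so only this step ties a weaker reading to the change from a single iodine atom to such a ring.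

As far as these compounds go, how a small group such as chloro or methyl, or a short chain such as propyl, would read on this carbon remains open. From the compounds shown here alone, it is also open whether a thiophene ring carrying an amine or a carboxylic acid would bring the reading back within the range of this assay.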